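Aspirin esters on a bicyclic diol core: plasma half-life

This account rests on a few compounds, and the source may have more. Where it says the series, first, only, none or still open, it means among the compounds named here.

Half-lives in an ADME assay on a cell-free system (plasma, Homo sapiens) for metabolic stability, with Plasma (Rattus norvegicus) as the target, read by HPLC, at pH 7.4; on this read-out lower numbers stand for a shorter-lived compound and higher numbers for a longer-lived compound:
compound 1 `CC(=O)Oc1ccccc1C(=O)O[C@H]1CO[C@H]2[C@@H]1OC[C@H]2O` gives 0.0183 h
compound 2 `CC(=O)Oc1ccccc1C(=O)O[C@H]1CO[C@H]2[C@@H]1OC[C@H]2OC(=O)c1ccc(C)cc1` gives 0.0362 h
compound 3 `CC(=O)Oc1ccccc1C(=O)O[C@H]1CO[C@H]2[C@@H]1OC[C@H]2O[N+](=O)[O-]` gives 0.00314 h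

Compound 2 holds the highest of the three numbers. Its nearest neighbour is compound 1, and the step of a 2.0-fold higher number from compound 1 to compound 2 (0.30 log units; within the scatter) lies within the scatter; its furthest is compound 3, reached by the step of a 12-fold lower number from compound 2 to compound 3 (1.06 log units; beyond the scatter).

Compound 4 `CC(=O)Oc1ccccc1C(=O)O[C@H]1CO[C@H]2[C@@H]1OC[C@H]2OC(=O)c1cccc(CO[N+](=O)[O-])c1` keeps the aroyl ester of compound 2 and differs only in that group: 3-((nitrooxy)methyl)phenyl in place of 4-methylphenyl on a carbonyl carbon. Within the data shown here, two measured steps bear on it. Both steps that bring a nitro onto the oxygen on the saturated carbon shortened the half-life, modestly in a 5.8-fold lower number from compound 1 to compound 3 (0.77 log units; beyond the scatter) and strongly in a 12-fold lower number from compound 2 to compound 3 (1.06 log units; beyond the scatter). Among the measured compounds shown here, in compound 4, however, that oxygen stays an ester, and the nitrooxy sits on the entering phenyl group, a situation no measured compound covers. Compound 4 is therefore expected to stay near compound 2, with at most a small downward step, a 1.3-fold lower number from compound 2 to compound 4 (0.11 log units; within the scatter), likely within the scatter. Compound 4 is estimated at 0.028 h, in the range 0.012 h to 0.065 h.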

Compound 4, half-life: 0.045 h
Estimate against measurement, compound 4: 1.6-fold (0.21 log units) below; the measured number falls inside the stated range.
By their numbers in this assay, from the lowest: compound 3; then compounds 1, 2 and 4 (each within the scatter of the next, the first and the last beyond it).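

In this assay the change on the carbonyl carbon to 3-((nitrooxy)methyl)phenyl gives a 1.2-fold higher number from compound 2 to compound 4 (0.09 log units; within the scatter) and so no readable shift in half-life, even though the entering group brings in a nitrogen and further oxygens. The earlier shortening, seen in a 12-fold lower number from compound 2 to compound 3 (1.06 log units; beyond the scatter) for nitro on the oxygen on a saturated carbon, therefore does not carry over to a nitrooxy held on the entering phenyl group in this pair. Nothing at hand accounts for this difference between the two placements.

The compounds shown leave open whether a longer chain carrying the nitrooxy, or an amine or a carboxylic acid in its place, would keep the half-life at this level. They also leave open which of the ester groups in these compounds governs the short half-lives.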